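Swapping the Urea for a Benzyl on the Pyrrolidine Nitrogen

The compounds below may be only part of what the source reports. "The series", "measured", "known", "first", "only" and "open" are said of these compounds alone.

Compound 1 `O=C(CN1CCCC1)N1CCC(NS(=O)(=O)c2cc(S(=O)(=O)c3ccccc3)ccc2C(F)(F)F)CC1` gives 110 nM in an assay on isolated protein for binding affinity to secreted frizzled-related protein 1 (Homo sapiens), read by fluorescence; on this read-out higher numbers stand for weaker inhibition and lower numbers for stronger inhibition.
Compound 2 `CN(C)c1ccc(C(=O)N2CCC[C@H]2C(=O)N2CCC(NS(=O)(=O)c3cc(S(=O)(=O)c4ccccc4)ccc3C(F)(F)F)CC2)cc1` gives 110 nM in this assay.
Compound 3 `CC(C)(C)NC(=O)N1CCC[C@H]1C(=O)N1CCC(NS(=O)(=O)c2cc(S(=O)(=O)c3ccccc3)ccc2C(F)(F)F)CC1` gives 20 nM in this assay.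

Compound 3 stands lowest of the three numbers, and both steps toward it, a 5.5-fold lower number from compound 1 to compound 3 (0.74 log units; beyond the scatter) and a 5.5-fold lower number from compound 2 to compound 3 (0.74 log units; beyond the scatter), lie beyond the scatter. Compound 4 `O=C([C@@H]1CCCN1Cc1ccccc1)N1CCC(NS(=O)(=O)c2cc(S(=O)(=O)c3ccccc3)ccc2C(F)(F)F)CC1` has not yet been measured. Against compound 3 the change is benzyl in place of (tert-butyl)carbamoyl on an amine nitrogen in a ring. Among the measured compounds shown here, no measured step matches this change exactly. The step of a 5.5-fold lower number from compound 1 to compound 3 (0.74 log units; beyond the scatter) moved from a carbonyl carrying a pyrrolidin-1-ylmethyl, an amine nitrogen without a carbamoyl, to the tert-butylcarbamoyl-bearing ring; compound 4 again carries an amine nitrogen without a carbamoyl. The step of a 5.5-fold lower number from compound 2 to compound 3 (0.74 log units; beyond the scatter) exchanged the group on the carbamoyl carbonyl, whereas compound 4 loses that carbonyl entirely. Both steps place the tert-butylcarbamoyl of compound 3 at the lower number, so its removal is expected to raise the number, roughly back to where compound 1 and compound 2 sit. Compound 4 is expected to give about 90 nM, within a range from 30 nM to 300 nM. The expected step is a 4.5-fold higher number from compound 3 to compound 4 (0.65 log units; beyond the scatter).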

Compound 4, half-maximal inhibitory concentration: 1400 nM
Compound 4: middle estimate off by 16-fold (1.19 log units), on the low side, and the stated range ends below it.
By their numbers in this assay, from the lowest: compound 3; then compounds 1 and 2 (each within the scatter of the next); then compound 4.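

In this assay, among the compounds shown here, the amine nitrogen in the five-membered ring proves far more sensitive than the earlier compounds could show, with a 70-fold higher number from compound 3 to compound 4 (1.85 log units; beyond the scatter) when benzyl replaces (tert-butyl)carbamoyl, the largest step seen so far. Removing the carbamoyl also does not simply return the number to the level of the compounds without it: a 13-fold higher number from compound 2 to compound 4 (1.10 log units; beyond the scatter) follows when benzyl replaces (4-(dimethylamino)phenyl)carbonyl on the same nitrogen, and a 13-fold higher number from compound 1 to compound 4 (1.10 log units; beyond the scatter) follows when 1-benzylpyrrolidin-2-yl replaces (pyrrolidin-1-yl)methyl on a carbonyl carbon, so among compounds 2, 3 and 4 the only one with no carbonyl on that nitrogen gives the highest number. Nothing available here accounts for this gap.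

The compounds shown leave open whether the loss follows the missing carbonyl or the benzyl itself, a question that an acetyl, a benzoyl or a benzylcarbamoyl on that nitrogen could help to separate. They also leave open how a free secondary amine or a simple methyl at this place would compare with the benzyl of compound 4.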